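Lengthening the Propyl Chain of Compound 3

The compounds below may be only part of what the source reports. "The series", "measured", "known", "first", "only" and "open" are said of these compounds alone.

In a functional assay on A549 cells (Homo sapiens) for inhibition, read by MTT assay, with a stated time of 48 h (on this read-out lower numbers stand for stronger inhibition and higher numbers for weaker inhibition), compound 1 (`Brc1ccc2[nH]cc(C(c3ccccc3)c3c[nH]c4ccc(Br)cc34)c2c1`) gives 7500 nM, compound 2 (`Clc1ccc(C(c2c[nH]c3ccc(Br)cc23)c2c[nH]c3ccc(Br)cc23)cc1`) gives 8500 nM and compound 3 (`CCCC(c1c[nH]c2ccc(Br)cc12)c1c[nH]c2ccc(Br)cc12`) gives 6500 nM. These numbers all lie within the scatter of one another, so compound 3 cannot be told apart from the other two.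

Compound 4 (`CCCCCCCC(c1c[nH]c2ccc(Br)cc12)c1c[nH]c2ccc(Br)cc12`) differs from compound 3 in one place: butyl in place of hydrogen on a saturated chain carbon, four bonds along the chain from two aromatic carbons. Put simply, this is butyl in place of hydrogen on a saturated chain carbon, four bonds along the chain from two aromatic carbons, which turns propyl into heptyl.

Among the measured compounds shown here, no measured step lengthens a chain, so the evidence is indirect. Two steps change the group at the carbon that carries this chain: a 1.2-fold lower number from compound 1 to compound 3 (0.06 log units; within the scatter) and a 1.3-fold lower number from compound 2 to compound 3 (0.12 log units; within the scatter). Both stay within the scatter, as does the more remote a 1.1-fold higher number from compound 1 to compound 2 (0.05 log units; within the scatter). On that basis, no change beyond the scatter is expected in this assay, and the expected step is a 1.1-fold lower number from compound 3 to compound 4 (0.03 log units; within the scatter).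

For compound 4, the estimated value is 6000 nM, with an expected range of 2500 nM to 13000 nM.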

Compound 4, half-maximal inhibitory concentration: 3500 nM
Beside the measured number, compound 4's estimate is 1.7-fold (0.23 log units) above it; the range from low to high includes it.
By their numbers in this assay, from the lowest: compounds 4, 3, 1 and 2 (each within the scatter of the next, the first and the last beyond it).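

In this assay, lengthening the chain gives a 1.9-fold lower number from compound 3 to compound 4 (0.27 log units; within the scatter), so propyl and heptyl cannot be told apart at this position. Heptyl does, however, show something the earlier compounds did not: a change at the carbon bound to two aromatic carbons can move the number beyond the scatter. Heptyl in place of phenyl gives a 2.1-fold lower number from compound 1 to compound 4 (0.33 log units; beyond the scatter), and heptyl in place of 4-chlorophenyl gives a 2.4-fold lower number from compound 2 to compound 4 (0.39 log units; beyond the scatter), both modest, whereas propyl stayed within the scatter of those same two groups. No evidence on the cause of these steps is available.

On these data alone, whether a longer chain such as decyl, or a chain ending in an amine or a carboxylic acid, would move the number beyond the scatter from compound 3 stays open. So does the result for a chain of in-between length, such as pentyl.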